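Thiophen-2-yl in place of phenyl: working notes

The source may hold more compounds than are shown below. What is called first, only, known or untested is meant among the compounds shown, and "the series" means these compounds.

- compound 1 `Cc1ccc(S(=O)(=O)Oc2ccccc2/C=C(\C#N)C(=O)Nc2nnc(C)s2)cc1` gives 78%
- compound 2 `N#C/C(=C\c1ccccc1OS(=O)(=O)c1ccc([N+](=O)[O-])cc1)C(=O)Nc1nnc(-c2cccs2)s1` gives 23%
- compound 3 `Cc1ccc(S(=O)(=O)Oc2cccc(/C=C(\C#N)C(=O)Nc3nnc(-c4ccccc4)s3)c2)cc1` gives 63%

In a functional assay on HL-60 cells (Homo sapiens) for inhibition, read by CCK-8 assay, with a stated time of 48 h, tested at 20 uM (a lower number here means less inhibition of growth, a higher number more inhibition of growth at the concentration tested), compound 3 gives 63% and stands second highest of the three, below compound 1 and above compound 2, both gaps beyond the scatter. The next compound is compound 4 `Cc1ccc(S(=O)(=O)Oc2cccc(/C=C(\C#N)C(=O)Nc3nnc(-c4cccs4)s3)c2)cc1` and the change is thiophen-2-yl in place of phenyl on an aromatic carbon. Going by the values given here, no measured pair isolates this change. Compound 2 also carries thiophen-2-yl and gives 23% but differs from compound 3 elsewhere too, so it supports only a slight downward expectation. The expected change is a number 4 percentage points lower from compound 3 to compound 4 (within the scatter) (estimated as small and downward, not beyond the scatter). The estimate for compound 4 is 59% (expected range 40% to 78%).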

Compound 4, percent growth inhibition at one concentration: 62%
The estimate for compound 4 lay 3 percentage points below the measured number; the range from low to high includes it.
By their numbers in this assay, from the lowest: compound 2; then compounds 4 and 3 (each within the scatter of the next); then compound 1.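

In this assay the change of phenyl to thiophen-2-yl on this aromatic carbon now has a clean pair, with a step of a number 1 percentage points lower from compound 3 to compound 4 (within the scatter) and so no separation between the two groups at this position. Going by these compounds alone, compound 2 also carries thiophen-2-yl but differs elsewhere too, so only this pair isolates the change. No available measurement bears on why the two groups read alike.

Open, on these data alone, is whether an amine or a carboxylic acid on this carbon would hold the number. Also open, as far as these compounds go, is whether the same change reads alike with the other substitution patterns of the shared core.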